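Acetamido to methoxy on the aniline ring of the shared core

This account rests on a few compounds, and the source may have more. Where it says the series, first, only, none or still open, it means among the compounds named here.

Measured compounds:
- compound 1 `Cc1cccc(Nc2nccc(-c3cc(C)oc3C)n2)c1`: 28500 nM
- compound 2 `CC(=O)Nc1ccc(Nc2nccc(-c3cccnc3)n2)cc1`: 3600 nM
- compound 3 `CN(C)c1ccc(Nc2nccc(-c3cccs3)n2)cc1`: 900 nM

In a functional assay for inhibition, with Homo sapiens as the target (a higher number here means a weaker inhibitor, a lower number a stronger inhibitor), compound 1 gives 28500 nM. In this assay compound 2 gives 3600 nM, the second highest of the three numbers, and compound 3 gives 900 nM. Compound 2 stands closer to compound 3 than to compound 1, and both of its gaps lie beyond the scatter. Within the data shown here, the three compounds differ in more than one place, so no single step between measured compounds can be read off; the values show only that compound 3 sits lowest and compound 1 highest among them.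

Compound 4 `COc1ccc(Nc2nccc(-c3cccnc3)n2)cc1` is not yet measured. Compared with compound 2 the change is methoxy in place of acetamido on an aromatic carbon. Both groups carry one hydrogen-bond acceptor; the hydrogen-bond donor of the acetamido group is lost.

Among the measured compounds shown here, no measured pair isolates this change, so the expectation rests on compound 2 alone. The step from compound 2 to compound 4 is expected to be small, within or only slightly beyond the scatter, with no clear direction: a 1.2-fold lower number from compound 2 to compound 4 (0.08 log units; within the scatter). Compound 4 is therefore estimated at 3000 nM, with a range from 800 nM to 12000 nM.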

Compound 4, half-maximal inhibitory concentration: 1700 nM
Estimate against measurement, compound 4: 1.8-fold (0.25 log units) above; low and high end bracket the measured number.
By their numbers in this assay, from the lowest: compounds 3 and 4 (each within the scatter of the next); then compound 2; then compound 1.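

In this assay, among these compounds, methoxy in place of acetamido on an aromatic carbon para to a large group gives a 2.1-fold lower number from compound 2 to compound 4 (0.33 log units; beyond the scatter), a modest step but the first reading of a single change, and it shows that the number at this position responds to the group placed there. The acetamido group is not needed to keep the number at the level of compound 2, since compound 4, which has methoxy and no hydrogen-bond donor there, gives a lower number. The change alters the size of the group and removes the hydrogen-bond donor in one step, and nothing measured here separates the two or explains the shift.

A simple amine, a carboxylic acid or a longer chain such as ethoxy at the same place would show whether the trend extends beyond methoxy and whether the hydrogen-bond donor matters on its own. Among the compounds shown here, with only this pair isolating the change, it remains open whether methoxy in place of acetamido gives a similar step when another ring is carried on the shared core.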